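Reversing the sulfonamide attachment in compound 3

A few compounds are considered here, and "the series" means these few. Any claim that something is new, unique, unknown or untested is made for them only; others in the source may bear on it.

compound 1 `Oc1cccc2cc(-c3ccc(F)cc3)ccc12`: < 10%
compound 2 `O=C(O)c1ccc(-c2ccc3c(O)cccc3c2)cc1`: < 10%
compound 3 `CNS(=O)(=O)c1ccc(-c2ccc3c(O)cccc3c2)cc1`: 12%

Of the compounds shown here, three have been measured in an assay for binding affinity to 17-beta-hydroxysteroid dehydrogenase type 1 (Homo sapiens), with a stated time of 20 min, tested at 1 uM; on this read-out lower numbers stand for less inhibition and higher numbers for more inhibition at the one concentration tested (going by the name of the read-out). Compound 1 gives < 10%, which is a limit of the assay rather than a number. Compound 2 gives < 10%, likewise a limit. Going by the values given here, compound 3 gives 12%, the only actual number among the three. The remaining two values are limits: the limit of < 10% in this assay, at which 2 of the 3 values shown sit. Among the compounds with values here, compound 3 therefore stands as the one compound with a readable result, though that result is small.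

Compound 4 `CS(=O)(=O)Nc1ccc(-c2ccc3c(O)cccc3c2)cc1` has not yet been measured. It differs from compound 3 in one place: methanesulfonamido in place of methylsulfamoyl on an aromatic carbon. Within the data shown here, no measured step covers this change directly. The nearest comparisons are a number at least 2 percentage points higher from compound 1 to compound 3 (that floor lies within the scatter) and a number at least 2 percentage points higher from compound 2 to compound 3 (that floor lies within the scatter), each setting only a small floor that lies within the scatter, while a step that the two limits leave unreadable from compound 1 to compound 2 cannot be read from two limits. Changing the group in this part of the molecule has so far moved the read-out little, so the expected step is a number 1 percentage points lower from compound 3 to compound 4 (within the scatter), nothing beyond the scatter. Compound 4 is estimated at 11%, between 4% and 20%, with a real chance that only a limit is reported.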

Compound 4, a percentage reported as inhibition, at one concentration (the size of the read-out at that concentration, not a potency): 52%
Compound 4: the middle estimate sits 41 percentage points below what was measured; the measured number lies above the stated range.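

Compound 3 and compound 4 carry the same atoms in this group, para to a large group, and differ only in how they are joined, yet in this assay putting methanesulfonamido in place of methylsulfamoyl gives a number 40 percentage points higher from compound 3 to compound 4 (beyond the scatter). So at this position the way the group is attached counts, not just which atoms it holds, which the earlier compounds could not show. The other two comparisons read a number at least 42 percentage points higher from compound 2 to compound 4 (beyond the scatter) and a number at least 42 percentage points higher from compound 1 to compound 4 (beyond the scatter), and these are only floors, because compound 1 and compound 2 each give a limit: the limit of < 10% in this assay, at which 2 of the 4 values shown sit.

From the compounds shown here alone, it stays open whether the sulfonyl part is needed at all, a question that an acetamido group or a plain amine here would address. Also open, going by these compounds, is whether a longer chain in place of the methyl keeps the read-out.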